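A 2,6-Difluorophenyl Counterpart to Compound 3

A few compounds are considered here, and "the series" means these few. Any claim that something is new, unique, unknown or untested is made for them only; others in the source may bear on it.

In a functional assay on HCT-116 cells (Homo sapiens) for inhibition, read by CCK-8 assay, with a stated time of 72 h (on this read-out higher numbers stand for weaker inhibition and lower numbers for stronger inhibition), compound 1 `Nc1ccccc1NC(=O)c1ccc(CNC(=O)c2n[nH]cc2NC(=O)c2c(F)cccc2Cl)cc1` gives 700 nM and compound 2 `Nc1ccccc1NC(=O)c1ccc(CNC(=O)c2n[nH]cc2NC(=O)c2c(Cl)cccc2Cl)cc1` gives 710 nM. Chloro in place of fluoro thus gives a 1.0-fold higher number from compound 1 to compound 2 (0.01 log units; within the scatter). Compound 3 `COc1ccccc1C(=O)Nc1c[nH]nc1C(=O)NCc1ccc(C(=O)Nc2ccccc2N)cc1` gives 3680 nM, the highest number of the three and so the weakest inhibition in this small set.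

Compound 4 `Nc1ccccc1NC(=O)c1ccc(CNC(=O)c2n[nH]cc2NC(=O)c2c(F)cccc2F)cc1` has not yet been measured. Its difference from compound 3 is 2,6-difluorophenyl in place of 2-methoxyphenyl on a carbonyl carbon.

Two measured steps change the group at this same place, a 5.3-fold higher number from compound 1 to compound 3 (0.72 log units; beyond the scatter) and a 5.2-fold higher number from compound 2 to compound 3 (0.71 log units; beyond the scatter). Both are modest and beyond the scatter. Run in reverse, they point towards stronger inhibition, so a step of similar size towards a lower number is expected here. The expected change is a 4.6-fold lower number from compound 3 to compound 4 (0.66 log units; beyond the scatter). Among the compounds with values here, no measured compound carries the 2,6-difluorophenyl group itself, so the range is kept wide. For compound 4 the estimated value is 800 nM, with an expected range from 350 nM to 1900 nM.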

Compound 4, half-maximal inhibitory concentration: 1130 nM
Compound 4: the middle estimate sits 1.4-fold (0.15 log units) below what was measured; the measured number falls inside the stated range.
By their numbers in this assay, from the lowest: compounds 1, 2 and 4 (each within the scatter of the next); then compound 3.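

In this assay the 2,6-difluorophenyl group also gives a 3.3-fold lower number from compound 3 to compound 4 (0.51 log units; beyond the scatter) and so adds a third halogen-bearing group that stands clear of the 2-methoxyphenyl group on this carbonyl carbon. The steps of a 1.6-fold higher number from compound 2 to compound 4 (0.20 log units; within the scatter) and a 1.6-fold higher number from compound 1 to compound 4 (0.21 log units; within the scatter) are both within the scatter, so compounds 1, 2 and 4 cannot be told apart here and exchanging fluoro and chloro on this ring has no resolved effect among these three. No data bearing on the reason for the gap to compound 3 are available.

The compounds shown leave open whether that gap goes with the methoxy group itself or with a ring carrying one group instead of two. A 2-fluorophenyl or a 2,6-dimethoxyphenyl group at this place would separate those two readings.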